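Forecasting compound 4 from three measured relatives

The source may hold more compounds than are shown below. What is called first, only, known or untested is meant among the compounds shown, and "the series" means these compounds.

The measured compounds so far:
- Compound 1, `C=CC(=O)Oc1cc(C(F)(F)F)cc(C(F)(F)F)c1` — in an ADME assay for pharmacokinetics, read by LC-MS, in phosphate buffer, with a stated time of 72 h, at pH 7.4, tested at 250 uM (on this read-out higher numbers stand for a longer-lived compound and lower numbers for a shorter-lived compound), compound 1 gives < 0.017 h, which is a limit of the assay, not a number.
- Compound 2, `O=C1C=CC(=O)N1c1cc(C(F)(F)F)cc(C(F)(F)F)c1` — in this assay compound 2 gives < 0.017 h, again a limit rather than a number.
- Compound 3, `C#Cc1cc(C(F)(F)F)cc(C(F)(F)F)c1` — in this assay compound 3 gives 5.9 h.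

Among the measured compounds shown here, compound 3 therefore holds the only real number among the three; the other two sit at the limit described by the limit of < 0.017 h in this assay, at which 2 of the 3 values shown sit. The steps toward compound 3 are both large: an at least 340-fold higher number from compound 1 to compound 3 (2.54 log units; beyond the scatter) and an at least 340-fold higher number from compound 2 to compound 3 (2.54 log units; beyond the scatter). The step between compounds 1 and 2 cannot be read because both values are limits: a step that the two limits leave unreadable from compound 1 to compound 2.

Compound 4, `O=C(CBr)c1cc(C(F)(F)F)cc(C(F)(F)F)c1`, differs from compound 3 in one place: (bromomethyl)carbonyl in place of ethynyl on an aromatic carbon. For the measured compounds named here, none of the measured steps involves a (bromomethyl)carbonyl group, so the measured steps bear on it only loosely. What they do show is that changing the group at this aromatic carbon can move the half-life by a very large amount, and that the ethynyl compound is the longest-lived of the three. On that basis the number for compound 4 is expected to be lower than that of compound 3, with the size of the drop highly uncertain: a 3.9-fold lower number from compound 3 to compound 4 (0.59 log units; beyond the scatter). The estimate for compound 4 is 1.5 h, with an expected range from 0.1 h to 15 h.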

Compound 4, half-life: < 0.017 h
Compound 4: only a limit was reported; the forecaster's own chance of this, stated with the estimate: 30%; middle value at least 88-fold (1.94 log units) from the limit.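

In this assay, putting (bromomethyl)carbonyl in place of ethynyl on this aromatic carbon gives an at least 340-fold lower number from compound 3 to compound 4 (2.54 log units; beyond the scatter), so a group with neither the ester link of compound 1 nor the ring of compound 2 can also produce a large drop. Compound 4 gives < 0.017 h, which is a limit of the assay and not a number, so the true size of that step could be larger still. Three different groups at this position now sit at the floor of the read-out, with only the ethynyl of compound 3 giving a real number, and the steps among compounds 1, 2 and 4 cannot be read: the limit of < 0.017 h in this assay, at which 3 of the 4 values shown sit.

The compounds shown leave open how these three rank against one another, and which part of the new group goes with the loss, the bromine or the carbonyl. A plain acetyl group or a (chloromethyl)carbonyl group on the same carbon would help separate those two parts, particularly if either gave a real number rather than a limit.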